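Ester variants of a glycosylated acid in a cell assay

The source may hold more compounds than are shown below. What is called first, only, known or untested is meant among the compounds shown, and "the series" means these compounds.

The series is read in a functional assay on SK-BR-3 cells (Homo sapiens) for antiproliferative activity, read by MTT assay, with a stated time of 72 h; a higher number here means a weaker inhibitor, a lower number a stronger inhibitor. Compound 1 `C/C=C1/[C@H](O[C@@H]2O[C@H](CO)[C@@H](O)[C@H](O)[C@H]2O)OC=C(C(=O)OC)[C@H]1CC(=O)O` gives only a limit of the assay there: compound 1 stands at > 15000 nM, and so its own number is not known, as the limit of > 15000 nM in this assay, at which 1 of the 2 values shown sits, records. Compound 2 `C/C=C1/[C@H](O[C@@H]2O[C@H](CO)[C@@H](O)[C@H](O)[C@H]2O)OC=C(C(=O)OC)[C@H]1CC(=O)OCCCCCCCCCCCCCCC`, the pentadecyl ester, gives 1600 nM in this assay. Compound 3 `C/C=C1/[C@H](O[C@@H]2O[C@H](CO)[C@@H](O)[C@H](O)[C@H]2O)OC=C(C(=O)OC)[C@H]1CC(=O)OC` is the methyl ester, not yet measured. Compound 3 differs from compound 1 by methyl in place of hydrogen on an oxygen next to a carbonyl group. Among the compounds with values here, no measured step joins these two compounds, so the size of the change can only be expected, not read off. Compound 2 shows that capping the acid can give a measurable number, but the short methyl group is a far smaller change. The step of an at least 1.8-fold lower number from compound 1 to compound 3 (0.27 log units; that floor lies within the scatter) is expected to be a gain, modest and uncertain. Compound 3 is estimated at 8000 nM, between 2500 nM and 25000 nM, with a real chance that this assay again reports only a limit.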

Compound 3, half-maximal inhibitory concentration: > 15000 nM
Compound 3: no number, only a limit; the forecaster's own chance of this, stated with the estimate: 35%; middle value at least 1.8-fold (0.27 log units) from the limit.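

In this assay, within the data shown here, compound 3 gives only a limit, > 15000 nM, and compound 1 also stands at a limit, so no step between these two compounds can be read. Open, going by these compounds, is at which ester chain, from the methyl ester of compound 3 to the pentadecyl ester of compound 2, a measurable number first appears.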